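The source may report more compounds than this note shows. Statements on the series, on what has been measured and on what is new or still open speak of the compounds shown alone.

Of the compounds shown here, three of the shared core have been measured so far, and they sit at one level. Compound 1 `C/C(=N\N=C1/SCC(=O)N1Cc1cccc(F)c1)c1cccs1` gives 1360000 nM in a physicochemical assay, with a stated time of 90 min; a higher number here means that more compound is needed for the effect, a lower number that less compound is needed. Compound 2 `C/C(=N/N=C1\SCC(=O)N1Cc1ccc(F)cc1)c1cccs1` gives 1370000 nM in this assay, and compound 3 `C/C(=N/N=C1\SCC(=O)N1Cc1ccccc1[N+](=O)[O-])c1cccs1` gives 1120000 nM. Compound 2 holds the highest of the three numbers, but its gaps to compound 1 and to compound 3 both lie within the scatter, so no order among the three can be read from these values. Compound 4 `C/C(=N/N=C1\SCC(=O)N1Cc1ccc(F)cc1)c1ccccn1` is the next member; it differs from compound 2 by pyridin-2-yl in place of thiophen-2-yl on a carbon with a double bond to nitrogen. Going by the values given here, no measured pair in the set isolates this change, so there is nothing to set its size against. With the three measured values resting at one level, the expectation for this assay is no step beyond the scatter in either direction. The step from compound 2 to compound 4 is accordingly expected to be a 1.1-fold lower number from compound 2 to compound 4 (0.02 log units; within the scatter). For compound 4 the value expected in this assay is 1300000 nM, with a range from 500000 nM to 3500000 nM.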

Compound 4, half-maximal effective concentration: 1160000 nM
For compound 4 the middle estimate is 1.1-fold (0.05 log units) above the measured one; the range from low to high includes it.
By their numbers in this assay, from the lowest: compounds 3, 4, 1 and 2 (each within the scatter of the next).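

The step at the carbon with a double bond to nitrogen can now be read: in this assay, pyridin-2-yl in place of thiophen-2-yl gives a 1.2-fold lower number from compound 2 to compound 4 (0.07 log units; within the scatter), so exchanging this five-membered aromatic ring for a six-membered one leaves the number at the level of the series. The earlier compounds shown here all carried thiophen-2-yl here, so they did not vary this position. No measured finding accounts for the result.

From the compounds shown here alone, whether that level holds with groups of another kind at this carbon, such as an amine, a carboxylic acid or a longer chain, remains open. Also open, going by these compounds, is whether the same exchange gives a step of similar size alongside the other groups on the shared core in compound 1 and compound 3.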